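The compounds below may be only part of what the source reports. "The series", "measured", "known", "first", "only" and "open" are said of these compounds alone.

Working notes on the series.

Of the compounds shown here, three of the shared core have numbers so far. In a functional assay (muscle tissue) with Cavia porcellus as the target (on this read-out lower numbers stand for an effect already at smaller amounts and higher numbers for an effect only at larger amounts of compound), compound 1 `COC(=O)C1=C(C)N=C(C)/C(=C(\O)OC)C1c1ccccc1N` gives 39800 nM and stands highest of the three, well beyond the scatter from the other two. Compound 2 `COC(=O)C1=C(C)N=C(C)/C(=C(\O)OC)C1c1cc([N+](=O)[O-])ccc1Cl` gives 30.2 nM in this assay, and compound 3 `COC(=O)C1=C(C)N=C(C)/C(=C(/O)OC)C1c1c(F)cccc1Cl` gives 7.59 nM. Compound 2 and compound 3 both carry halogen on the aryl ring and both sit far lower than compound 1; whether compound 2 and compound 3 differ from each other by more than the scatter is not told here, so no order between them is claimed.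

Compound 4 `COC(=O)C1=C(C)N=C(C)/C(=C(\O)OC)C1c1ccc(Cl)cc1Cl` is not yet measured in this assay. Relative to compound 1 the change is 2,4-dichlorophenyl in place of 2-aminophenyl on a saturated ring carbon. Among the compounds with values here, no measured pair differs in exactly this way, so the expectation rests on the three numbers alone: compound 2 and compound 3, each with a 2-chlorophenyl-type ring and no donor on the aryl ring, sit far below compound 1, and compound 4 also loses the aryl donor and gains two chlorines. A large downward step, of the order seen from compound 1 to compound 2 and compound 3, is expected, estimated as a 1300-fold lower number from compound 1 to compound 4 (3.12 log units; beyond the scatter). Compound 4 is therefore expected to give about 30 nM in this assay, within a range of 5 nM to 200 nM.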

Compound 4, half-maximal effective concentration: 640 nM
Compound 4: the middle estimate sits 21-fold (1.33 log units) below what was measured; measured number outside the range, above it.
By their numbers in this assay, from the lowest: compound 3; then compound 2; then compound 4; then compound 1.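

The first step read at this position comes from 2,4-dichlorophenyl in place of 2-aminophenyl on the saturated ring carbon, which gives in this assay a 62-fold lower number from compound 1 to compound 4 (1.79 log units; beyond the scatter), so the read-out clearly responds to the aryl group carried there. Chlorine on the aryl ring does not by itself bring a compound down to the lowest numbers of the series: compound 4 stays at 640 nM, whereas compound 2 gives 30.2 nM and compound 3 gives 7.59 nM. Nothing available explains the size of this step or the place of compound 4 in the order.

The step swaps the whole aryl group, so it cannot say how much of the change belongs to losing the amine and how much to gaining the two chlorines. An unsubstituted phenyl on the same carbon would separate these two parts, while a methoxy group or a nitrile on the aryl ring would show whether the high number of compound 1 is particular to the amine.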